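Swapping the ring at the chain end: pyrrole to hydroxyphenyl

The compounds below may be only part of what the source reports. "The series", "measured", "known", "first", "only" and "open" are said of these compounds alone.

Measured compounds in an ADME assay on Vero cells (Chlorocebus sabaeus) for cytotoxicity, read by MTT assay; a lower number here means a stronger inhibitor, a higher number a weaker inhibitor:
- compound 1, `C=CCOc1cc(OC)c(C(=O)/C=C/c2ccccc2Br)c(OCC=C)c1`, 13900 nM
- compound 2, `C=CCOc1cc(OC)c(C(=O)/C=C/c2ccncc2)c(OCC=C)c1`, 2800 nM
- compound 3, `C=CCOc1cc(OC)c(C(=O)/C=C/c2ccc[nH]2)c(OCC=C)c1`, "not determined" (no result reported)

All three share one core and differ only in the ring at the far end of the double-bonded chain. Compound 3 stands without a number in this assay, so it cannot be placed against compound 1 or compound 2. Compound 4, `C=CCOc1cc(OC)c(C(=O)/C=C/c2ccc(O)cc2)c(OCC=C)c1`, carries the change (4-hydroxyphenyl in place of 1H-pyrrol-2-yl on a double-bonded chain carbon bound to a double-bonded chain carbon).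

Among the measured compounds shown here, the one step measured between two compounds at this same place is a 5.0-fold lower number from compound 1 to compound 2 (0.70 log units; beyond the scatter). It shows that exchanging the ring on this chain carbon can move the cytotoxicity number by a modest amount, and not always in a way that is easy to foresee. For the measured compounds named here, since compound 3 has no number of its own, no step can be computed from it, and the expectation for compound 4 has to rest on the span of the measured values alone.

Compound 4 is estimated at about 6000 nM, with a range from 1500 nM to 25000 nM.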

Compound 4, half-maximal inhibitory concentration: 76400 nM
Compound 4: middle estimate off by 13-fold (1.10 log units), on the low side; measured number outside the range, above it.
By their numbers in this assay, from the lowest: compound 2; then compound 1; then compound 4.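

In this assay, the ring on this double-bonded chain carbon can shift the number much further than the first step suggested: the 4-hydroxyphenyl ring gives a 27-fold higher number from compound 2 to compound 4 (1.44 log units; beyond the scatter) and a 5.5-fold higher number from compound 1 to compound 4 (0.74 log units; beyond the scatter). Compound 4 is therefore the weakest inhibitor of the three measured compounds, and the large gap from the pyridin-4-yl ring of compound 2 shows that two six-membered rings can behave very differently here. Nothing available explains why the 4-hydroxyphenyl ring gives so high a number.

The direct change from compound 3 to compound 4 cannot be read: compound 3 has no number. Also open, going by these compounds, is whether an amine or a methoxy group in place of the hydroxyl on the phenyl ring would keep the number close to that of compound 4.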